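The compounds below may be only part of what the source reports. "The series", "measured", "known", "first", "only" and "open" are said of these compounds alone.

Compound 1 `Cc1nc(N(C)C(=O)NC(=O)c2c(F)cccc2F)sc1C(=O)N/N=C/c1ccc(C(F)(F)F)cc1` gives the highest of the three numbers recorded so far in a functional assay on BCG823 cells (Homo sapiens) for inhibition, read by MTT assay, with a stated time of 72 h (a higher number here means a weaker inhibitor, a lower number a stronger inhibitor), at 65.5 ug/mL. Compound 2 `Cc1nc(N(C)C(=O)NC(=O)c2c(F)cccc2F)sc1C(=O)N/N=C/c1ccccc1C(F)(F)F` gives 7.88 ug/mL in this assay, and the change between them, 2-(trifluoromethyl)phenyl in place of 4-(trifluoromethyl)phenyl on a carbon with a double bond to nitrogen, gave an 8.3-fold lower number from compound 1 to compound 2 (0.92 log units; beyond the scatter). Compound 3 `CN(C(=O)NC(=O)c1ccc(Cl)c(Cl)c1)c1nc(C(F)(F)F)c(C(=O)N/N=C/c2cccc([N+](=O)[O-])c2)s1` differs from compound 1 in several places at once. In this assay compound 3 gives 4.87 ug/mL.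

Compound 4 `CN(C(=O)NC(=O)c1c(F)cccc1F)c1nc(C(F)(F)F)c(C(=O)N/N=C/c2ccc(C(F)(F)F)cc2)s1` is not yet measured. Relative to compound 1 the change is trifluoromethyl in place of methyl on an aromatic carbon. For the measured compounds named here, no measured pair isolates this change: the one recorded step concerns the aryl group on the hydrazone carbon, not the five-membered ring. Compound 3 carries a trifluoromethyl on that ring and gives a lower number, but its other differences leave the contribution of the ring substituent unresolved. Going by the values given here, the expected step is therefore a cautious one, a 2.2-fold lower number from compound 1 to compound 4 (0.34 log units; beyond the scatter), leaning toward a lower number only because compound 3, the single trifluoromethyl-bearing analogue, shows 4.87 ug/mL. For compound 4 the estimate in this assay is 30 ug/mL, with a range from 8 ug/mL to 90 ug/mL.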

Compound 4, half-maximal inhibitory concentration: 34.9 ug/mL
Estimate against measurement, compound 4: 1.2-fold (0.07 log units) below; low and high end bracket the measured number.
By their numbers in this assay, from the lowest: compounds 3 and 2 (each within the scatter of the next); then compounds 4 and 1 (each within the scatter of the next).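

In this assay, for the compounds shown here, trifluoromethyl in place of methyl on an aromatic carbon, next to the ring nitrogen, gives a 1.9-fold lower number from compound 1 to compound 4 (0.27 log units; within the scatter), the first reading that isolates this ring position. The position therefore accepts a group of four heavy atoms in place of one with no change beyond the scatter, at least with the 4-(trifluoromethyl)phenyl group on the carbon with a double bond to nitrogen. No measured evidence is available to explain this result.

From the compounds shown here alone, it remains open whether the same replacement would also have no resolved effect alongside the 2-(trifluoromethyl)phenyl group. Also open, going by these compounds, is how this assay would respond at the same ring carbon to a group of a different kind, such as an amine, a carboxylic acid or a longer alkyl chain.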